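Para-substituted anilides on the shared core: estimate for compound 4

The source may report more compounds than this note shows. Statements on the series, on what has been measured and on what is new or still open speak of the compounds shown alone.

Measured compounds:
compound 1 `CC(=O)Nc1ccc(NC(=O)c2cn(Cc3c(F)cccc3F)c3ccc(=O)[nH]c3c2=O)cc1` — 24 nM
compound 2 `N#Cc1ccc(NC(=O)c2cn(Cc3c(F)cccc3F)c3ccc(=O)[nH]c3c2=O)cc1` — 96 nM
compound 3 `N#Cc1cccc(NC(=O)c2cn(Cc3c(F)cccc3F)c3ccc(=O)[nH]c3c2=O)c1` — 1070 nM

In an in vitro assay on Sf21 cells for inhibition of high affinity 3',5'-cyclic-AMP phosphodiesterase 7A (Homo sapiens), read by scintillation proximity assay, with a stated time of 30 min (on this read-out lower numbers stand for stronger inhibition and higher numbers for weaker inhibition), compound 1 gives the lowest number of the three measured, compound 2 the nearest and compound 3 the furthest. The step of a 4.0-fold higher number from compound 1 to compound 2 (0.60 log units; beyond the scatter) is modest; the steps of a 45-fold higher number from compound 1 to compound 3 (1.65 log units; beyond the scatter) and an 11-fold higher number from compound 2 to compound 3 (1.05 log units; beyond the scatter) are large, so the two compounds with a substituent para to a large group sit well apart from the one carrying it elsewhere on the ring.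

Compound 4 `O=C(O)Cc1ccc(NC(=O)c2cn(Cc3c(F)cccc3F)c3ccc(=O)[nH]c3c2=O)cc1` is not yet measured in this assay. Its change from compound 1 is carboxymethyl in place of acetamido on an aromatic carbon, on an aromatic carbon of a six-membered aromatic ring of carbon only, para to a large group. Within the data shown here, no measured step exchanges one group for another at exactly this place with comparable make-up; the only step at this place, a 4.0-fold higher number from compound 1 to compound 2 (0.60 log units; beyond the scatter), shows that replacing acetamido there costs something but not much. Among the measured compounds shown here, an acid-bearing group has no precedent in the three measured compounds, so the expectation is wider than that step alone.

For compound 4 the expected step is a 2.5-fold higher number from compound 1 to compound 4 (0.40 log units; beyond the scatter), giving an estimate of 60 nM with a range from 15 nM to 300 nM.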

Compound 4, half-maximal inhibitory concentration: 176 nM
Compound 4: middle estimate off by 2.9-fold (0.47 log units), on the low side, within the range that was stated.
By their numbers in this assay, from the lowest: compound 1; then compounds 2 and 4 (each within the scatter of the next); then compound 3.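

In this assay, a second replacement of acetamido on the aromatic carbon para to a large group gives a step of modest size, a 7.3-fold higher number from compound 1 to compound 4 (0.87 log units; beyond the scatter), so compound 1 keeps the lowest number against both the cyano and the carboxymethyl replacement at this place. Cyano and carboxymethyl cannot be told apart here, a 1.8-fold higher number from compound 2 to compound 4 (0.26 log units; within the scatter), while the comparison with the 3-cyanophenyl anilide, a 6.1-fold lower number from compound 3 to compound 4 (0.78 log units; beyond the scatter), shows that a carboxymethyl group at this place also stays clear of the highest number in the set, so the three compounds with a group at this place all sit below compound 3 and none goes against that. Nothing available here accounts for the size of any of these steps.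

Still open, on these data alone, is whether an amine, a methyl ester or a longer carboxylic acid chain at this place would come closer to acetamido or stay level with cyano and carboxymethyl. Also open, as far as these compounds go, is whether carboxymethyl elsewhere on the ring would lose as much as cyano does, an 11-fold higher number from compound 2 to compound 3 (1.05 log units; beyond the scatter).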